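A few compounds are considered here, and "the series" means these few. Any claim that something is new, unique, unknown or untested is made for them only; others in the source may bear on it.

Of the compounds shown here, three built on one shared core have so far been tested in a functional assay on A549 cells (Homo sapiens) for cytotoxicity, read by MTT assay, with a stated time of 24 h; a lower number here means a stronger inhibitor, a higher number a weaker inhibitor. Compound 1 `C=CC1=C(C(=O)Nc2ccc(OCC)cc2)C(c2ccc(OC)cc2)OC1` carries a 4-ethoxyphenyl on its amide nitrogen, and in this assay compound 1 gives 17600 nM. Compound 2 `C=CC1=C(C(=O)Nc2ccccc2)C(c2ccc(OC)cc2)OC1` carries a plain phenyl there; in this assay compound 2 reaches only the limit of the assay, > 100000 nM, which is not a number. Compound 3 `C=CC1=C(C(=O)NCCC)C(c2ccc(OC)cc2)OC1` carries a propyl on that nitrogen, and in this assay compound 3 also stops at the limit > 100000 nM. Compound 3 therefore stands at the weak end of what the numbers show, described by a limit rather than a value; the limit of > 100000 nM in this assay, at which 2 of the 3 values shown sit, marks where two of the three results sit.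

Compound 4 `C=CC1=C(C(=O)Nc2ccccc2OC)C(c2ccc(OC)cc2)OC1` is the next compound: 2-methoxyphenyl in place of propyl on an amide-type nitrogen. Going by the values given here, two measured steps bear on this exchange. Read in reverse, an at least 5.6-fold higher number from compound 1 to compound 3 (0.75 log units; beyond the scatter), so an alkoxy-bearing aryl on the amide nitrogen gave a stronger inhibitor than propyl. By contrast, a step that the two limits leave unreadable from compound 2 to compound 3. The 2-methoxyphenyl of compound 4, like the 4-ethoxyphenyl of compound 1, bears an alkoxy group, which places compound 4 nearer to compound 1 than to compound 2. Compound 4 is therefore expected to move downward in number, with an at least 2.5-fold lower number from compound 3 to compound 4 (0.39 log units; beyond the scatter) as the expected step. The estimate for compound 4 in this assay is 40000 nM, within a range from 12000 nM to 120000 nM.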

Compound 4, half-maximal inhibitory concentration: > 100000 nM
Compound 4 was reported as a limit (the forecaster's own chance of this, stated with the estimate: 45%); at least 2.5-fold (0.39 log units) between middle value and limit.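

Moving from 4-ethoxyphenyl to 2-methoxyphenyl on the amide nitrogen gives a weaker result in this assay, with an at least 5.6-fold higher number from compound 1 to compound 4 (0.75 log units; beyond the scatter), so among the compounds shown, an alkoxy group on that aryl ring does not by itself bring a measurable value. Compound 2, compound 3 and compound 4 are all limits and not numbers, so the steps among them cannot be read, and nothing can be said about whether the methoxy group of compound 4 changes anything relative to plain phenyl or propyl. Going by these compounds alone, compound 1 remains the only compound with a true number, while the others share one ceiling: the limit of > 100000 nM in this assay, at which 3 of the 4 values shown sit.

The compounds shown leave open whether the result for compound 1 depends on the ethoxy group itself or on where it sits, a question that 4-methoxyphenyl and 2-ethoxyphenyl on the amide nitrogen could separate. Also open, going by these compounds, is whether a different group at this place, such as a 4-aminophenyl, a 4-carboxyphenyl or an alkyl chain longer than propyl, would give a value rather than a limit.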